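Fluorines in Place of Chlorine on a Thioether Enone

The source may report more compounds than this note shows. Statements on the series, on what has been measured and on what is new or still open speak of the compounds shown alone.

Compound 1 `O=C(/C(=C\c1ccc(Cl)cc1)Sc1ccc(Br)cc1)c1ccc(Br)cc1` has the lowest of the two numbers on record in a functional assay on DU-145 cells (Homo sapiens) for inhibition, read by trypan blue exclusion, with a stated time of 96 h (a lower number here means a stronger inhibitor of growth, a higher number a weaker inhibitor of growth), giving 1000 nM; compound 2 `O=C(/C(=C\c1ccc(O)cc1)S(=O)(=O)Cc1ccc(Cl)c(Cl)c1)c1ccc(Cl)cc1` gives 10000 nM in this assay, a difference beyond the scatter. Compound 3 `O=C(/C(=C\c1ccc(F)cc1F)Sc1ccc(Br)cc1)c1ccc(Br)cc1` has not yet been measured. It differs from compound 1 by 2,4-difluorophenyl in place of 4-chlorophenyl on a double-bonded chain carbon bound to a double-bonded chain carbon. Among the compounds with values here, no step between measured compounds is available for this change, so the step is expected to be small, within or near the scatter, leaning slightly weaker. Compound 3 is therefore estimated at 1500 nM, between 500 nM and 5000 nM, a step of a 1.5-fold higher number from compound 1 to compound 3 (0.18 log units; within the scatter).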

Compound 3, concentration for 50% growth inhibition: 1000 nM
Compound 3: the middle estimate sits 1.5-fold (0.18 log units) above what was measured; measured number inside the range.
By their numbers in this assay, from the lowest: compounds 1 and 3 (each within the scatter of the next); then compound 2.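

In this assay, within the data shown here, the only single-place step on record shows no change at the digits printed from compound 1 to compound 3 (within the scatter), with 2,4-difluorophenyl in place of 4-chlorophenyl on a double-bonded chain carbon bound to a double-bonded chain carbon. At this position, then, a ring with two fluorines and no chlorine serves as well as the chlorinated ring, at least for this one pair. No measurement here speaks to the reason for this.

As far as these compounds go, what an amine or a carboxylic acid on this ring would do remains open. So does whether the same exchange would leave the number unchanged on a core other than that of compound 1.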